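A few compounds are considered here, and "the series" means these few. Any claim that something is new, unique, unknown or untested is made for them only; others in the source may bear on it.

In a functional assay on LNCaP cells (Homo sapiens) for antiproliferative activity, read by propidium iodide staining, with a stated time of 96 h; a higher number here means a weaker inhibitor, a lower number a stronger inhibitor:
Compound 1 `CC(O)(CS(=O)(=O)c1ccc(F)cc1)C(=O)Nc1ccc(S(F)(F)(F)(F)F)cc1`: 18200 nM
Compound 2 `CC(O)(CS(=O)(=O)c1cccc(C(F)(F)F)c1)C(=O)Nc1ccc(S(F)(F)(F)(F)F)cc1`: 21000 nM
Compound 3 `CC(O)(CS(=O)(=O)c1ccc(OC(F)(F)F)cc1)C(=O)Nc1ccc(S(F)(F)(F)(F)F)cc1`: 92800 nM

Compound 3 has the highest number of the three and is the weakest inhibitor. Compound 4 `CC(O)(CS(=O)(=O)c1ccccc1OC(F)(F)F)C(=O)Nc1ccc(S(F)(F)(F)(F)F)cc1` is not yet measured. It carries 2-(trifluoromethoxy)phenyl in place of 4-(trifluoromethoxy)phenyl on a sulfonyl sulfur. Within the data shown here, no measured step shifts a group in this way, so the evidence is indirect. Other changes to this aryl group gave modest steps, a 5.1-fold higher number from compound 1 to compound 3 (0.71 log units; beyond the scatter) and a 4.4-fold higher number from compound 2 to compound 3 (0.65 log units; beyond the scatter). A modest step toward a lower number in this assay is therefore expected, with little certainty. The expected change is a 2.1-fold lower number from compound 3 to compound 4 (0.31 log units; beyond the scatter). For compound 4 the estimated value is 45000 nM, with an expected range from 15000 nM to 120000 nM.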

Compound 4, half-maximal inhibitory concentration: 12700 nM
Beside the measured number, compound 4's estimate is 3.5-fold (0.55 log units) above it; the whole stated range lies above it.
By their numbers in this assay, from the lowest: compounds 4, 1 and 2 (each within the scatter of the next); then compound 3.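

In this assay the same atoms, rearranged on the aryl group of the sulfonyl sulfur, give a 7.3-fold lower number from compound 3 to compound 4 (0.86 log units; beyond the scatter) when 2-(trifluoromethoxy)phenyl replaces 4-(trifluoromethoxy)phenyl, so the placement of this group counts and not only its identity. With a 1.7-fold lower number from compound 2 to compound 4 (0.22 log units; within the scatter) and a 1.4-fold lower number from compound 1 to compound 4 (0.16 log units; within the scatter) compound 4 stands level with those two compounds, and only compound 3 sits apart from the rest. Nothing measured here explains this effect of placement.

On these data alone, whether an amine or a carboxylic acid on this aryl group would hold the number at this level stays open. So does the effect of a longer chain on the sulfonyl sulfur in place of the aryl group.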